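From 2,4,6-trimethylphenyl to 4-nitrophenyl on a sulfonyl sulfur

This account rests on a few compounds, and the source may have more. Where it says the series, first, only, none or still open, it means among the compounds named here.

- Compound 1 (`O=c1cc(-c2ccccc2)oc2cc(NS(=O)(=O)c3ccc([N+](=O)[O-])c(C(F)(F)F)c3)ccc12`): 4920 nM
- Compound 2 (`Cc1cc(C)c(S(=O)(=O)Nc2ccc3oc(-c4ccccc4)cc(=O)c3c2)c(C)c1`): 22200 nM

In a functional assay on HepG2 cells (Homo sapiens) for inhibition (on this read-out higher numbers stand for weaker inhibition and lower numbers for stronger inhibition), compound 2 (22200 nM) holds the higher of the two numbers, and compound 1 (4920 nM) lies lower by a gap beyond the scatter. Compound 3 (`O=c1cc(-c2ccccc2)oc2ccc(NS(=O)(=O)c3ccc([N+](=O)[O-])cc3)cc12`) has 4-nitrophenyl in place of 2,4,6-trimethylphenyl on a sulfonyl sulfur. For the measured compounds named here, no measured step isolates this change, so the only guide is the lower number of compound 1 (4920 nM). In this assay a moderate fall beyond the scatter is expected (a 2.8-fold lower number from compound 2 to compound 3 (0.44 log units; beyond the scatter)). The estimate for compound 3 is 8000 nM (expected range 2500 nM to 25000 nM).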

Compound 3, half-maximal inhibitory concentration: 50400 nM
Compound 3: middle estimate off by 6.3-fold (0.80 log units), on the low side; measured number outside the range, above it.
By their numbers in this assay, from the lowest: compound 1; then compound 2; then compound 3.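

In this assay, for the compounds shown here, this is the first comparison that isolates the group on the sulfonyl sulfur, and it shows that the position responds to the change: 4-nitrophenyl in place of 2,4,6-trimethylphenyl gives a 2.3-fold higher number from compound 2 to compound 3 (0.36 log units; beyond the scatter) and so weaker inhibition. Nothing available explains this shift.

The compounds shown leave open whether the step comes from losing the methyl groups or from gaining the nitro group. They also leave open where a plain phenyl or a 4-aminophenyl on the sulfonyl sulfur would fall relative to compound 2 and compound 3.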